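Fluorine on the terminal phenyl of a triazole carboxamide

A few compounds are considered here, and "the series" means these few. Any claim that something is new, unique, unknown or untested is made for them only; others in the source may bear on it.

The pair measured so far shares one core. Compound 1 `COc1cc2c(Oc3ccc(NC(=O)c4cn(-c5ccccc5)nn4)cc3F)ccnc2cc1OCCCN1CCCCC1` gives 180 nM in a functional assay on HT-29 cells (Homo sapiens) for cytotoxicity, read by MTT assay, with a stated time of 72 h; on this read-out higher numbers stand for weaker inhibition and lower numbers for stronger inhibition. Compound 2 `COc1cc2c(Oc3ccc(NC(=O)c4cn(-c5ccccc5)nn4)cc3F)ccnc2cc1OCCCN1CCC(C)CC1` carries a methyl on a saturated ring carbon of the piperidine and gives 190 nM in this assay. The step of a 1.1-fold higher number from compound 1 to compound 2 (0.02 log units; within the scatter) is within the scatter, so compound 2 stands next to compound 1 with no separation that the assay can resolve; of the two numbers it holds the higher one, but only by a margin that means nothing here.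

Compound 3 `COc1cc2c(Oc3ccc(NC(=O)c4cn(-c5ccccc5F)nn4)cc3F)ccnc2cc1OCCCN1CCC(C)CC1` is the next step from compound 2: fluoro in place of hydrogen on an aromatic carbon. Among the compounds with values here, no measured step touches this aromatic carbon; the single step known, a 1.1-fold higher number from compound 1 to compound 2 (0.02 log units; within the scatter), sits on the piperidine and says nothing about the phenyl on the triazole. With no guide from the data, compound 3 is expected to move little from compound 2, and the expected step of a 1.1-fold higher number from compound 2 to compound 3 (0.02 log units; within the scatter) is taken as none beyond the scatter. On that basis compound 3 is estimated at 200 nM in this assay, with a range from 90 nM to 450 nM.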

Compound 3, half-maximal inhibitory concentration: 210 nM
Compound 3: the middle estimate sits 1.1-fold (0.02 log units) below what was measured; low and high end bracket the measured number.
By their numbers in this assay, from the lowest: compounds 1, 2 and 3 (each within the scatter of the next).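

Phenyl to 2-fluorophenyl on the triazole is the first measured change at this aromatic carbon, and in this assay it reads a 1.1-fold higher number from compound 2 to compound 3 (0.04 log units; within the scatter). A single fluoro ortho to a large group is therefore accommodated here without a change that the assay can resolve, and this phenyl joins the piperidine of the earlier step as a second place where one small substitution leaves the number within the scatter. No measurement at hand bears on this result, so it stands as an observation without an explanation.

The compounds shown leave open whether a larger group on this phenyl, such as methoxy, trifluoromethyl or a primary amine, would leave the number as undisturbed as the fluoro did, given that fluoro is the only substituent present on this ring. Also open, from the compounds shown here alone, is whether the 2-fluorophenyl would read the same with the unsubstituted piperidine of compound 1, and whether a charged group such as a carboxylic acid on this phenyl would be accommodated at all.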